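The source may report more compounds than this note shows. Statements on the series, on what has been measured and on what is new or still open speak of the compounds shown alone.

Measured compounds in a functional assay on the whole organism with Rattus norvegicus as the target; a higher number here means that more compound is needed for the effect, a lower number that less compound is needed:
compound 1, `Cc1nn(C)c2c1C(c1ccccc1)=NCC(=O)N2`, gives 16 mg/kg.
compound 2, `Cc1nn(C)c2c1C(c1cccc(Cl)c1)=NCC(=O)N2`, gives a limit of the assay, > 500 mg/kg.
compound 3, `CCc1nn(C)c2c1C(c1ccc(F)cc1)=NCC(=O)N2C`, gives a limit of the assay, > 500 mg/kg.

Within the data shown here, the single measured step, an at least 31-fold higher number from compound 1 to compound 2 (1.49 log units; beyond the scatter), carries compound 2 to the limit of > 500 mg/kg in this assay, at which 2 of the 3 values shown sit. Compound 2 thus stands not at a number but at the upper limit of this assay, and compound 3 stands at the same limit.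

Compound 4, `CCCCn1nc(C)c2c1NC(=O)CN=C2c1cccc(Cl)c1`, differs from compound 2 by propyl in place of hydrogen on a saturated chain carbon bound to an aromatic nitrogen. Among the measured compounds shown here, no measured step alters that place, so the only guide is where compound 2 stands. Compound 4 is therefore expected to stay near that limit, with a step of an at least 1.2-fold lower number from compound 2 to compound 4 (0.09 log units; that floor lies within the scatter). Compound 4 is estimated at 400 mg/kg, from 100 mg/kg to 1000 mg/kg.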

Compound 4, minimum effective dose: > 500 mg/kg
Compound 4: no number, only a limit; the forecaster's own chance of this, stated with the estimate: 70%; at least 1.2-fold (0.09 log units) between middle value and limit.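

In this assay compound 4 gives > 500 mg/kg, a limit of the assay. Among these compounds, compound 2 stands at a limit as well, so no step from it to compound 4 can be read. The compounds shown leave open what propyl in this place does to a compound with a measured number, such as compound 1.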